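Shortening the carboxy chain: compound 3 to compound 4

The source may report more compounds than this note shows. Statements on the series, on what has been measured and on what is new or still open speak of the compounds shown alone.

In a functional assay on HeLa cells (Homo sapiens) for cytotoxicity, read by MTT assay, with a stated time of 72 h (on this read-out higher numbers stand for weaker inhibition and lower numbers for stronger inhibition), compound 3 `CC1=CCC[C@H]2[C@](C)(CC3=CC(=O)C=C(NCCC(=O)O)C3=O)[C@@H](C)CC[C@]12C` gives 8870 nM. Compound 2 `CC1=CCC[C@H]2[C@](C)(CC3=CC(=O)C=C(N[C@@H](CC(C)C)C(=O)O)C3=O)[C@@H](C)CC[C@]12C` gives 7720 nM, within the scatter of compound 3, and compound 1 `CC1=CCC[C@H]2[C@](C)(CC3=CC(=O)C=CC3=O)[C@@H](C)CC[C@]12C` gives 18100 nM, the highest number of the three. Compound 4 `CC1=CCC[C@H]2[C@](C)(CC3=CC(=O)C=C(NCC(=O)O)C3=O)[C@@H](C)CC[C@]12C` differs from compound 3 by carboxy in place of carboxymethyl on a saturated chain carbon bound to an amine nitrogen. The closest evidence is a 1.1-fold higher number from compound 2 to compound 3 (0.06 log units; within the scatter), a change on the amine nitrogen. Adding the amine chains gave modest steps: a 2.3-fold lower number from compound 1 to compound 2 (0.37 log units; beyond the scatter) and a 2.0-fold lower number from compound 1 to compound 3 (0.31 log units; beyond the scatter). Compound 4 keeps a carboxy-bearing amine chain, so no step beyond the scatter is expected in this assay. The expected step is a 1.0-fold lower number from compound 3 to compound 4 (0.02 log units; within the scatter). Compound 4 is estimated at 8500 nM, with an expected range of 4500 nM to 16000 nM.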

Compound 4, half-maximal inhibitory concentration: 19900 nM
For compound 4 the middle estimate is 2.3-fold (0.37 log units) below the measured one; measured number outside the range, above it.
By their numbers in this assay, from the lowest: compounds 2 and 3 (each within the scatter of the next); then compounds 1 and 4 (each within the scatter of the next).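

In this assay the chain on the amine nitrogen is sensitive to small changes: carboxy in place of carboxymethyl gives a 2.2-fold higher number from compound 3 to compound 4 (0.35 log units; beyond the scatter), and hydrogen in place of isobutyl gives a 2.6-fold higher number from compound 2 to compound 4 (0.41 log units; beyond the scatter). The (carboxymethyl)amino group keeps none of the gain seen with the other two amine chains, giving a 1.1-fold higher number from compound 1 to compound 4 (0.04 log units; within the scatter). No evidence shown bears on the reason for this shift.

The compounds shown leave open whether a longer chain on the amine nitrogen keeps the lower numbers. They also leave open whether the carboxy group is needed, which a methyl ester or a primary amide in its place would test.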